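A Second Chloro on the Benzylidene Ring

The source may hold more compounds than are shown below. What is called first, only, known or untested is meant among the compounds shown, and "the series" means these compounds.

Compound 2 `CC(=O)OC/C(=C/c1ccccc1Cl)C(=O)c1ccccc1` gives 24000 nM in a functional assay on HeLa cells (Homo sapiens) for inhibition, read by sulforhodamine B assay, with a stated time of 48 h; a lower number here means a stronger inhibitor of growth, a higher number a weaker inhibitor of growth. Compound 1 `CC(=O)OC/C(=C\c1ccc(Cl)cc1Cl)C(=O)c1ccccc1` gives 16000 nM in this assay; of the two numbers measured, compound 2 carries the larger, yet the gap to compound 1 lies within the scatter. Compound 3 `CC(=O)OC/C(=C/c1ccc(Cl)cc1Cl)C(=O)c1ccccc1` is not yet measured; it differs from compound 2 by chloro in place of hydrogen on an aromatic carbon. Within the data shown here, no measured pair shows this change, so no step beyond the scatter is expected in either direction. Compound 3 is estimated at 18000 nM, between 8000 nM and 40000 nM. The expected step of a 1.3-fold lower number from compound 2 to compound 3 (0.12 log units; within the scatter) is small, within the scatter.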

Compound 3, concentration for 50% growth inhibition: 22000 nM
The estimate for compound 3 lay 1.2-fold (0.09 log units) below the measured number, and the stated range covers the measured number.
By their numbers in this assay, from the lowest: compounds 1, 3 and 2 (each within the scatter of the next).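

Chloro in place of hydrogen at this position, meta to a chloro group and para to a large group, gives a 1.1-fold lower number from compound 2 to compound 3 (0.04 log units; within the scatter) in this assay. Changing the double bond from E to Z with both chloro groups present gives a 1.4-fold higher number from compound 1 to compound 3 (0.14 log units; within the scatter), so neither change moves the number beyond the scatter. This second step reads on configuration alone: the fact that compounds 1 and 3 differ only in the configuration as drawn

Going by these compounds, whether an amine or a carboxylic acid in place of this chloro would give a step beyond the scatter stays open. So does the effect of configuration when this chloro is absent.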